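A few compounds are considered here, and "the series" means these few. Any claim that something is new, unique, unknown or untested is made for them only; others in the source may bear on it.

Of the compounds shown here, two have so far been measured in a functional assay on HeLa cells (Homo sapiens) for antiproliferative activity, read by sulforhodamine B assay, with a stated time of 48 h; on this read-out lower numbers stand for stronger inhibition and higher numbers for weaker inhibition. Compound 1 `O=C(Nc1ccccc1)Nc1ccc(S(=O)(=O)Nc2ccnc3cc(C(F)(F)F)ccc23)cc1` gives 41000 nM. Compound 2 `N=C(N)NS(=O)(=O)c1ccc(N/C(S)=N\c2ccnc3cc(C(F)(F)F)ccc23)cc1` gives 23900 nM, the lowest of the two numbers, though its gap to compound 1 lies within the usual scatter, so the two cannot really be told apart. Compound 3 `Cc1noc(NS(=O)(=O)c2ccc(N/C(S)=N\c3ccnc4cc(C(F)(F)F)ccc34)cc2)c1C` has not yet been measured. It differs from compound 2 in one place: a group of 7 heavy atoms (5 carbon, 1 nitrogen, 1 oxygen; one five-membered aromatic ring with 2 hetero atoms) in place of a group of 3 heavy atoms (1 carbon, 2 nitrogen; no ring), on a sulfonamide nitrogen. Among the compounds with values here, no step between two measured compounds that differ in only one place is available, so there is nothing of that kind to lean on, and the shared core is kept untouched while only the group on the sulfonamide nitrogen is exchanged. A step of modest size is expected in this assay, somewhat more likely toward a lower number than a higher one, yet one that may well stay within the scatter. For compound 3 the estimate is 18000 nM, with a range from 6000 nM to 50000 nM, which is an expected step of a 1.3-fold lower number from compound 2 to compound 3 (0.12 log units; within the scatter).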

Compound 3, half-maximal inhibitory concentration: "not active" (no number reported)
Nothing numeric was reported for compound 3; there is nothing to compare the estimate with.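

Within the data shown here, compound 3 is reported as "not active" in this assay without a number, so no step from compound 2 to compound 3 can be read. Nothing available bears on this result. On these data alone, how far the 3,4-dimethyl-1,2-oxazol-5-yl group shifts the number therefore stays open.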